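The source may report more compounds than this note shows. Statements on the series, on what has been measured and on what is new or still open speak of the compounds shown alone.

Working notes on the diaryl urea series.

The series is followed in a functional assay on CNE-2 cells (Homo sapiens) for cytotoxicity, read by MTT assay, with a stated time of 3 days; on this read-out lower numbers stand for stronger inhibition and higher numbers for weaker inhibition. Compound 1 `Cc1cc(C)nc(Oc2ccc(NC(=O)Nc3ccccc3)cc2)n1` carries a plain phenyl urea on the ether-linked core; in this assay compound 1 is recorded as "not determined" (no result reported). Compound 2 `Cc1cc(C)nc(Oc2ccc(NC(=O)Nc3ccc(F)cc3)cc2)n1` has the same ether-linked core with a fluoro on the far phenyl ring, and in this assay compound 2 gives 46900 nM. Compound 3 `Cc1cc(C)nc(Sc2ccc(NC(=O)Nc3ccccc3)cc2)n1` keeps the plain phenyl urea but joins the core through a thioether, and in this assay compound 3 gives 22000 nM. Of the two numbers in hand, compound 3 gives the lower one; compound 2 and compound 3 differ in two places at once, so their values are simply set side by side here.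

Compound 4 `Cc1cc(C)nc(Sc2ccc(NC(=O)Nc3ccc(Cl)cc3)cc2)n1` extends compound 3 by one change: chloro in place of hydrogen on an aromatic carbon. For the measured compounds named here, no measured pair isolates this change, and the single halogenated entry, compound 2, sits on the other core. The expectation is therefore a modest step, if any, toward a lower number, with the step from a 1.5-fold lower number from compound 3 to compound 4 (0.17 log units; within the scatter) treated as uncertain in size. Compound 4 is estimated at 15000 nM, with a range from 5000 nM to 40000 nM.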

Compound 4, half-maximal inhibitory concentration: 13500 nM
Beside the measured number, compound 4's estimate is 1.1-fold (0.05 log units) above it; measured number inside the range.
By their numbers in this assay, from the lowest: compounds 4 and 3 (each within the scatter of the next); then compound 2.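

For the compounds shown here, compound 4 gives the first step that isolates a single change: in this assay, chloro in place of hydrogen on an aromatic carbon, para to a large group, gives a 1.6-fold lower number from compound 3 to compound 4 (0.21 log units; within the scatter). At this position, then, phenyl to 4-chlorophenyl on the shared core leaves compound 3 and compound 4 within the usual scatter of each other, so the pair shows no resolved effect of the chloro. Nothing at hand points to a reason for this reading.

As far as these compounds go, whether an amine, a carboxylic acid or a methoxy group at the same position would give a step beyond the scatter remains open. The steps that would compare the ether and thioether links, or fluoro with hydrogen on the ether-linked core, cannot be read from compound 1.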